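The source may report more compounds than this note shows. Statements on the series, on what has been measured and on what is new or still open speak of the compounds shown alone.

Two compounds share one core and differ only in the ring attached to the carbonyl carbon. Compound 1 `COc1cc(-c2cc(/C=C/C(=O)c3ccc(N)cc3)[nH]n2)cc(OC)c1OC` carries a 4-aminophenyl group there, and in a functional assay on K562 cells (Homo sapiens) for inhibition, read by sulforhodamine B assay, with a stated time of 48 h (on this read-out lower numbers stand for stronger inhibition of growth and higher numbers for weaker inhibition of growth), compound 1 gives 23600 nM. Within the data shown here, compound 2 `COc1cc(-c2cc(/C=C/C(=O)c3ccc(Cl)c(Cl)c3)[nH]n2)cc(OC)c1OC` carries a 3,4-dichlorophenyl group instead, and in this assay compound 2 gives 64400 nM, the highest of the two numbers measured; the single step of a 2.7-fold higher number from compound 1 to compound 2 (0.44 log units; beyond the scatter) shows weaker growth inhibition for compound 2.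

Compound 3 `COc1ccc(C(=O)/C=C/c2cc(-c3cc(OC)c(OC)c(OC)c3)n[nH]2)cc1OC` is not yet measured. It differs from compound 2 by one change: 3,4-dimethoxyphenyl in place of 3,4-dichlorophenyl on a carbonyl carbon. Among the measured compounds shown here, only the step from compound 1 to compound 2 speaks to swapping the ring on the carbonyl carbon, and it was modest. Compound 3 is therefore expected to give a somewhat lower number than compound 2, a step of a 1.8-fold lower number from compound 2 to compound 3 (0.26 log units; within the scatter) in this assay. The estimate for compound 3 is 35000 nM, with a range from 12000 nM to 100000 nM.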

Compound 3, concentration for total growth inhibition: 7120 nM
The estimate for compound 3 lay 4.9-fold (0.69 log units) above the measured number; measured number outside the range, below it.
By their numbers in this assay, from the lowest: compound 3; then compound 1; then compound 2.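

The size of the ring swap on this carbonyl carbon now looks larger than the first pair suggested: 3,4-dimethoxyphenyl in place of 3,4-dichlorophenyl gives a 9.0-fold lower number from compound 2 to compound 3 (0.96 log units; beyond the scatter) in this assay and so moves growth inhibition well beyond the scatter. The step of a 3.3-fold lower number from compound 1 to compound 3 (0.52 log units; beyond the scatter) also places the 3,4-dimethoxyphenyl group ahead of the 4-aminophenyl group, so among these three compounds, compound 3 inhibits growth most strongly. The entering group brings 2 hydrogen-bond acceptors and 2 more heavy atoms, but no measurement here explains why the number falls.

The compounds shown cannot separate the contribution of each methoxy group, so a ring carrying a single methoxy group would be informative. A 3,4,5-trimethoxyphenyl or 3,4-dihydroxyphenyl group at this carbonyl carbon also remains an open case.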